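Meta-substituent swap on the benzyl ring: chloro for ethyl

The source may hold more compounds than are shown below. What is called first, only, known or untested is meant among the compounds shown, and "the series" means these compounds.

Measured compounds in an assay on CHO cells for displacement of a labelled ligand from prostaglandin E2 receptor EP3 subtype (Mus musculus), read by scintillation counting, with a stated time of 60 min; on this read-out lower numbers stand for stronger inhibition and higher numbers for weaker inhibition:
compound 1, `O=C(O)CCCSCCN1C(=O)OC[C@@H]1/C=C/[C@@H](O)Cc1ccccc1`, 6400 nM
compound 2, `O=C(O)CCCSCCN1C(=O)OC[C@@H]1/C=C/[C@@H](O)Cc1cccc(C(F)(F)F)c1`, 1600 nM
compound 3, `CCc1cccc(C[C@H](O)/C=C/[C@H]2COC(=O)N2CCSCCCC(=O)O)c1`, 2700 nM

Compound 3 stands second highest of the three numbers in this assay; its nearest neighbour is compound 2, which gives 1600 nM, and the step of a 1.7-fold higher number from compound 2 to compound 3 (0.23 log units; within the scatter) is within the scatter. The step of a 2.4-fold lower number from compound 1 to compound 3 (0.37 log units; beyond the scatter) is beyond the scatter, as is a 4.0-fold lower number from compound 1 to compound 2 (0.60 log units; beyond the scatter). Both substituents tried so far on that aromatic carbon thus lower the number relative to the unsubstituted compound 1, with no separation between them.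

Compound 4, `O=C(O)CCCSCCN1C(=O)OC[C@@H]1/C=C/[C@@H](O)Cc1cccc(Cl)c1`, is the next member: chloro in place of ethyl on an aromatic carbon. For the measured compounds named here, no measured step involves chloro, so the bearing steps are only the two substituent introductions above. They suggest that a substituent on this carbon is what matters, and that its identity changes little; the expected step of a 1.4-fold lower number from compound 3 to compound 4 (0.13 log units; within the scatter) is therefore small and may fall within the scatter. For compound 4 in this assay the estimate is 2000 nM, with a range from 900 nM to 4500 nM.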

Compound 4, inhibition constant: 630 nM
For compound 4 the middle estimate is 3.2-fold (0.50 log units) above the measured one; measured number outside the range, below it.
By their numbers in this assay, from the lowest: compound 4; then compounds 2 and 3 (each within the scatter of the next); then compound 1.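

In this assay the identity of the substituent on this aromatic carbon matters after all: chloro in place of ethyl gives a 4.3-fold lower number from compound 3 to compound 4 (0.63 log units; beyond the scatter) and chloro in place of trifluoromethyl gives a 2.5-fold lower number from compound 2 to compound 4 (0.40 log units; beyond the scatter), so chloro separates from both groups, which themselves remain within the scatter of each other. Set against the unsubstituted parent, the change gives a 10-fold lower number from compound 1 to compound 4 (1.01 log units; beyond the scatter), the only large step in the series, and with all its steps beyond the scatter compound 4 is the strongest of the four on this read-out. Nothing available accounts for chloro standing apart from ethyl and trifluoromethyl.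

Still open, from the compounds shown here alone, is whether fluoro, bromo or methoxy on the same carbon would match chloro or stay with ethyl and trifluoromethyl. Also open, going by these compounds, is whether chloro on another carbon of the ring would keep the step.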